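Amide to sulfonamide on a shared chromone-ether core

A few compounds are considered here, and "the series" means these few. Any claim that something is new, unique, unknown or untested is made for them only; others in the source may bear on it.

Measured so far in an assay on isolated protein for inhibition of Rho-associated protein kinase 2 (Homo sapiens), read by scintillation counting, radiometric assay and 33P incorporation, with a stated time of 40 min, in the presence of a further agent that is not named here; on this read-out lower numbers stand for stronger inhibition and higher numbers for weaker inhibition:
Compound 1 `CCOc1ccc(C(=O)Nc2cccc(NC(=O)COc3ccc4c(=O)ccoc4c3)c2)cc1` gives 9 nM.
Compound 2 `Cc1nc(C(=O)Nc2cccc(NC(=O)COc3ccc4c(=O)ccoc4c3)c2)cs1` gives 33 nM.

Among the compounds with values here, compound 2 stands at the higher of the two numbers; the single measured step, a 3.7-fold higher number from compound 1 to compound 2 (0.56 log units; beyond the scatter), is modest but beyond the scatter. Compound 3 `Cn1ccc(S(=O)(=O)Nc2cccc(NC(=O)COc3ccc4c(=O)ccoc4c3)c2)n1` has not been measured. Its difference from compound 2 is a group of 9 heavy atoms (4 carbon, 2 nitrogen, 2 oxygen, 1 sulfur; one five-membered aromatic ring with 2 hetero atoms) in place of a group of 8 heavy atoms (5 carbon, 1 nitrogen, 1 oxygen, 1 sulfur; one five-membered aromatic ring with 2 hetero atoms), on a nitrogen on an aromatic ring: the carbonyl that linked the ring to the aromatic nitrogen gives way to a sulfonyl group, and the methyl-substituted thiazole to a methyl-substituted pyrazole. Within the data shown here, the one step in hand exchanges one ring for another while the carbonyl stays in place, so it bears only loosely on compound 3; nothing measured here addresses the carbonyl-to-sulfonyl exchange itself, and the expectation is correspondingly uncertain. Given that the only ring exchange seen already moved the number upward, a further upward step is expected for compound 3, roughly a 3.0-fold higher number from compound 2 to compound 3 (0.48 log units; beyond the scatter). The estimate for compound 3 in this assay is 100 nM, with a range from 20 nM to 500 nM.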

Compound 3, half-maximal inhibitory concentration: 1350 nM
Compound 3: middle estimate off by 14-fold (1.13 log units), on the low side; measured number outside the range, above it.
By their numbers in this assay, from the lowest: compound 1; then compound 2; then compound 3.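

In this assay, within the data shown here, the exchange on a nitrogen on an aromatic ring gives a 41-fold higher number from compound 2 to compound 3 (1.61 log units; beyond the scatter), a large step where the one earlier step, a 3.7-fold higher number from compound 1 to compound 2 (0.56 log units; beyond the scatter), was only modest. Measured against the 4-ethoxyphenyl amide, the sulfonyl-linked methyl-substituted pyrazole gives a 150-fold higher number from compound 1 to compound 3 (2.18 log units; beyond the scatter), so the three groups show that the number at this position can vary widely while the rest of the structure stays the same, with compound 1 lowest and compound 3 highest. No evidence is available on why the number rises so sharply with this exchange.

Linker and ring change together between compound 2 and compound 3, so these compounds leave open how much of the rise belongs to the sulfonyl group and how much to the pyrazole, a question that a methyl-substituted pyrazole on a carbonyl or a 2-methyl-1,3-thiazol-4-yl on a sulfonyl would separate. They also leave open whether a 4-ethoxyphenyl on a sulfonyl would stay near compound 1 or rise as compound 3 did, and how an amine or a carboxylic acid on the ring would read.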